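Shortening the isobutyl chain to ethyl

The compounds below may be only part of what the source reports. "The series", "measured", "known", "first", "only" and "open" are said of these compounds alone.

Measured in a functional assay (strain AB) with Danio rerio as the target, read by microscopy, with a stated time of 1 h; on this read-out lower numbers stand for an effect already at smaller amounts and higher numbers for an effect only at larger amounts of compound:
- compound 1 `CC(C)(C)OC(=O)CCC[N+]1(C)CCc2c(sc(NC(=O)Nc3ccc(Cl)cc3)c2C(N)=O)C1` gives 250 nM
- compound 2 `CC(C)[N+]1(C)CCc2c(sc(NC(=O)Nc3ccc(Cl)cc3)c2C(N)=O)C1` gives 960 nM
- compound 3 `CC(C)C[N+]1(C)CCc2c(sc(NC(=O)Nc3ccc(Cl)cc3)c2C(N)=O)C1` gives 380 nM

Compound 3 stands close to compound 1, with a 1.5-fold higher number from compound 1 to compound 3 (0.18 log units; within the scatter), whereas a 2.5-fold lower number from compound 2 to compound 3 (0.40 log units; beyond the scatter). Compound 4 `CC[N+]1(C)CCc2c(sc(NC(=O)Nc3ccc(Cl)cc3)c2C(N)=O)C1` has not yet been measured. It carries methyl in place of isopropyl on a saturated chain carbon bound to an amine nitrogen in a ring, which also reads as isobutyl to ethyl. Among the measured compounds shown here, two modest steps bear on this change: the one just given from compound 2 and a 3.8-fold higher number from compound 1 to compound 2 (0.58 log units; beyond the scatter). Neither involves ethyl itself, so only a modest rise is expected. The expected step is a 2.0-fold higher number from compound 3 to compound 4 (0.30 log units; within the scatter) in this assay. For compound 4 the estimated value is 750 nM, with an expected range from 300 nM to 1800 nM.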

Compound 4, half-maximal effective concentration: 1960 nM
Compound 4: middle estimate off by 2.6-fold (0.42 log units), on the low side; the whole stated range lies below it.
By their numbers in this assay, from the lowest: compounds 1 and 3 (each within the scatter of the next); then compound 2; then compound 4.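

In this assay, among the compounds shown here, this position proves more sensitive to loss of carbon than the earlier compounds showed, with a 5.2-fold higher number from compound 3 to compound 4 (0.71 log units; beyond the scatter) for isobutyl to ethyl. Ethyl also falls behind isopropyl, with a 2.0-fold higher number from compound 2 to compound 4 (0.31 log units; beyond the scatter) on that change, and behind the ester-bearing chain, with a 7.8-fold higher number from compound 1 to compound 4 (0.89 log units; beyond the scatter) in all, placing it at the high end of the four compounds. No evidence shown gives a reason for this rise. Open, going by these compounds, is how a methyl, an unbranched butyl chain or a carboxylic acid in place of the tert-butyl ester would read at this nitrogen.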